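The compounds below may be only part of what the source reports. "The series", "measured", "known", "first", "only" and "open" are said of these compounds alone.

Three analogues of a shared core have been measured in a functional assay on HCC827 cells (Homo sapiens) for inhibition, read by MTT assay, with a stated time of 48 h, tested at 10 uM; a lower number here means less inhibition, a higher number more inhibition at the concentration tested (going by the name of the read-out). Compound 1 `CCc1cccc(Nc2cc(NC(=O)Nc3cc(OC)cc(OC)c3)ncn2)c1` gives 52.6% in this assay. Compound 2 `COc1cc(NC(=O)Nc2cc(Nc3ccc(F)c(Cl)c3)ncn2)cc(OC)c1` gives 53.1% in this assay. Compound 3 `COc1cc(NC(=O)Nc2cc(Nc3cc(I)ccc3OC)ncn2)cc(OC)c1` gives 71% in this assay. The three differ only in the group on a nitrogen on an aromatic ring. The step of a number 0.5 percentage points higher from compound 1 to compound 2 (within the scatter) does not separate compounds 1 and 2. The steps of a number 18.4 percentage points higher from compound 1 to compound 3 (beyond the scatter) and a number 17.9 percentage points higher from compound 2 to compound 3 (beyond the scatter) do separate them from compound 3, which stands highest of the three numbers, nearest compound 2 and furthest compound 1.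

Compound 4 `COc1cc(NC(=O)Nc2cc(Nc3ccc(C)c(C)c3)ncn2)cc(OC)c1` is the next member, not yet measured. 3,4-dimethylphenyl in place of 5-iodo-2-methoxyphenyl on a nitrogen on an aromatic ring Both measured steps that bear on this place run toward 5-iodo-2-methoxyphenyl and gain inhibition; read backwards, leaving that group for one resembling 3-ethylphenyl in compound 1 or 3-chloro-4-fluorophenyl in compound 2 is expected to give back roughly what those steps gained. Given a number 0.5 percentage points higher from compound 1 to compound 2 (within the scatter), 3,4-dimethylphenyl is expected to land near that pair rather than near compound 3. Compound 4 is therefore expected to give 55% in this assay, with a range from 42% to 68%. For compound 4 this corresponds to an expected step of a number 16 percentage points lower from compound 3 to compound 4 (beyond the scatter).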

Compound 4, a percentage reported as inhibition, at one concentration (the size of the read-out at that concentration, not a potency): 45.7%
Compound 4: the middle estimate sits 9.3 percentage points above what was measured; the range from low to high includes it.
By their numbers in this assay, from the lowest: compounds 4, 1 and 2 (each within the scatter of the next); then compound 3.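

Notes on the group on a nitrogen on an aromatic ring, read in this assay: the step of a number 25.3 percentage points lower from compound 3 to compound 4 (beyond the scatter) shows that 3,4-dimethylphenyl, which carries only carbon in place of the iodine and methoxy of 5-iodo-2-methoxyphenyl, also falls clearly short of that group. The steps of a number 7.4 percentage points lower from compound 2 to compound 4 (within the scatter) and a number 6.9 percentage points lower from compound 1 to compound 4 (within the scatter) do not separate it from 3-chloro-4-fluorophenyl or 3-ethylphenyl, so among the four compounds shown, three different substituted phenyl groups form one cluster and only compound 3 stands apart, with a halogen-bearing group in compound 2 sitting in the cluster alongside the two carbon-only groups. No measurement at hand explains why this position responds in this way.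

Compound 3 differs from the others in both its iodine and its methoxy group, so the compounds shown cannot tell whether either one alone, or only the two together, accounts for its higher number. Also open, as far as these compounds go, is how this position would respond to a phenyl bearing a basic amine such as morpholine or a carboxylic acid, or to a longer alkyl chain in place of the aromatic ring.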